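Catechol Methylation in a Thiophene Sulfonamide Urea Series

A few compounds are considered here, and "the series" means these few. Any claim that something is new, unique, unknown or untested is made for them only; others in the source may bear on it.

Measured compounds:
Compound 1, `Cc1ccc(-c2ccsc2S(=O)(=O)NCCNC(=O)Nc2cc(C(F)(F)F)cc(C(F)(F)F)c2)c(Oc2ccc(O)c(O)c2)c1`, 9700 nM
Compound 2, `COc1ccc(Oc2ccccc2-c2ccsc2S(=O)(=O)N2CCN(C(=O)Nc3ccc([N+](=O)[O-])cc3)CC2)cc1OC`, > 50000 nM
Compound 3, `O=C(Nc1ccc([N+](=O)[O-])cc1)N1CCN(S(=O)(=O)c2sccc2-c2ccccc2Oc2ccc(O)c(O)c2)CC1`, > 20000 nM

Within the data shown here, in a functional assay on HeLa cells (Homo sapiens) for inhibition, read by CCK-8 assay, with a stated time of 48 h (on this read-out higher numbers stand for weaker inhibition and lower numbers for stronger inhibition), compound 1 gives 9700 nM, the only number among the three. For compound 3 the assay reports only a limit, > 20000 nM, sitting at the limit of > 20000 nM in this assay, at which 1 of the 3 values shown sits. For compound 2 it likewise reports only a limit, > 50000 nM, sitting at the limit of > 50000 nM in this assay, at which 1 of the 3 values shown sits. The change between these two, (3,4-dimethoxyphenyl in place of 3,4-dihydroxyphenyl on an oxygen on an aromatic ring), therefore yields a step that the two limits leave unreadable from compound 3 to compound 2. How the core of compound 1 differs from that of compound 3 is not broken down here.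

Compound 4, `COc1ccc(Oc2cc(C)ccc2-c2ccsc2S(=O)(=O)NCCNC(=O)Nc2cc(C(F)(F)F)cc(C(F)(F)F)c2)cc1OC`, arises from compound 1 by the same change at the same place, (3,4-dimethoxyphenyl in place of 3,4-dihydroxyphenyl on an oxygen on an aromatic ring). With the measured instance of this change unreadable, the expectation rests on compound 1 alone at 9700 nM, and the step is expected to be a 2.6-fold higher number from compound 1 to compound 4 (0.41 log units; beyond the scatter). Compound 4 is expected to give 25000 nM, estimated between 8000 nM and 60000 nM.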

Compound 4, half-maximal inhibitory concentration: 10200 nM
Compound 4: middle estimate off by 2.5-fold (0.39 log units), on the high side, and the stated range covers the measured number.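

In this assay, 3,4-dimethoxyphenyl in place of 3,4-dihydroxyphenyl on the core of compound 1 gives a 1.1-fold higher number from compound 1 to compound 4 (0.02 log units; within the scatter), so on this core the two groups cannot be told apart. The same change on the core of compound 3 cannot be read, since compound 3 and compound 2 are both reported only as limits. This single readable step therefore does not show that the result carries from one core to another.

The compounds shown leave open what size the change would have on the core of compound 3. They also leave open how a phenyl bearing an amine or a carboxylic acid in place of 3,4-dihydroxyphenyl would read in this assay.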